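Turning one stereocentre from R to S

A few compounds are considered here, and "the series" means these few. Any claim that something is new, unique, unknown or untested is made for them only; others in the source may bear on it.

Measured in a functional assay on MCF7 cells (Homo sapiens) for antiproliferative activity, read by MTT assay, with a stated time of 72 h; a higher number here means a weaker inhibitor, a lower number a stronger inhibitor:
- compound 1 `NC1CCc2nc(-c3ccncc3)nc(Nc3cccc(F)c3)c2C1`: 13900 nM
- compound 2 `N[C@@H]1CCc2nc(-c3ccncc3)nc(Nc3cccc(F)c3)c2C1`: 16200 nM
- compound 3 `CN(C)c1ccc(Nc2nc(-c3ccncc3)nc3c2CC(N)CC3)cc1`: 15800 nM

Compound 2 stands level with the other two, since all three values lie within the scatter of one another. Compound 4 `N[C@H]1CCc2nc(-c3ccncc3)nc(Nc3cccc(F)c3)c2C1` differs from compound 2 only in configuration: the two compounds have the same atoms and bonds and differ only in configuration as drawn: 1 of 1 stereo elements differ; a stereocentre at a saturated ring carbon is drawn R in compound 2 and S in compound 4. The stereocentre at a saturated ring carbon is drawn R in compound 2 and S in compound 4.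

The closest evidence is a 1.2-fold higher number from compound 1 to compound 2 (0.07 log units; within the scatter), and it comes with the fact that one of compounds 1 and 2 is drawn with a defined configuration and the other without, at the place where they differ. The other measured step, a 1.1-fold higher number from compound 1 to compound 3 (0.06 log units; within the scatter), lies at a different place and leaves the stereocentre untouched. Within the data shown here, no compound drawn S has been measured yet. If compound 1 holds both configurations, its small step to compound 2 leaves little room for compound 4 to stand apart.

In this assay, no change beyond the scatter is therefore expected, and the estimated step is a 1.2-fold lower number from compound 2 to compound 4 (0.06 log units; within the scatter). For compound 4 the expected value is 14000 nM, within an estimated range of 7000 nM to 28000 nM.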

Compound 4, half-maximal inhibitory concentration: 14200 nM
Compound 4: middle estimate off by 1.0-fold (0.01 log units), on the low side, within the range that was stated.
By their numbers in this assay, from the lowest: compounds 1, 4, 3 and 2 (each within the scatter of the next).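

The change from R to S at the saturated ring carbon can now be read directly in this assay, and it gives a 1.1-fold lower number from compound 2 to compound 4 (0.06 log units; within the scatter), with nothing else in the structures to weigh against it: the fact that compounds 2 and 4 differ only in the configuration as drawn. The S form also stands level with the compound drawn without a configuration, at a 1.0-fold higher number from compound 1 to compound 4 (0.01 log units; within the scatter). Where the earlier compounds could only suggest it, compound 2 and compound 4 together show that, with 3-fluorophenyl on the nitrogen, the drawn configuration at this carbon leaves the antiproliferative read-out within the scatter.

On these data alone, what stays open is whether configuration would matter with a different group on this carbon, such as a hydroxyl or an acetamide in place of the amine. As far as these compounds go, it is equally open whether the same holds with 4-(dimethylamino)phenyl in place of 3-fluorophenyl, or in cells other than those of this assay.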